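The source may report more compounds than this note shows. Statements on the series, on what has been measured and on what is new or still open speak of the compounds shown alone.

Compound 1 `COc1cc2c(cc1OC)CN(CCn1cc(COc3ccc([N+](=O)[O-])cc3)nn1)CC2` gives > 100000 nM in an ADME assay on K562/A02 cells (Homo sapiens) for cytotoxicity, read by MTT assay, with a stated time of 48 h (a higher number here means a weaker inhibitor, a lower number a stronger inhibitor), which is a limit of the assay rather than a number. Compound 2 `COc1cc2c(cc1OC)CN(CCn1cc(COc3ccc(C(C)(C)C)cc3)nn1)CC2` likewise gives > 100000 nM in this assay, again only a limit. The step that the two limits leave unreadable from compound 1 to compound 2 therefore cannot be sized. Compound 3 `COc1cc2c(cc1OC)CN(CCn1cc(COc3ccccc3C(C)(C)C)nn1)CC2` differs from compound 2 by 2-(tert-butyl)phenyl in place of 4-(tert-butyl)phenyl on an oxygen on a saturated carbon. For the measured compounds named here, with the limit of > 100000 nM in this assay, at which 2 of the 2 values shown sit, no measured step is readable, so no direction or size beyond the scatter can be expected for a number no higher from compound 2 to compound 3 (the limit leaves the size open). Compound 3 is estimated at 100000 nM in this assay, within 30000 nM to 300000 nM, most likely reported as a limit again.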

Compound 3, half-maximal inhibitory concentration: > 100000 nM
Compound 3: only a limit was reported; the forecaster's own chance of this, stated with the estimate: 80%; the middle value sits exactly at the limit.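

No step can be read among compound 1, compound 2 and compound 3, because all three stop at the same limit rather than giving a number: the limit of > 100000 nM in this assay, at which 3 of the 3 values shown sit. The compounds shown leave open how the 4-nitrophenyl, 4-(tert-butyl)phenyl and 2-(tert-butyl)phenyl groups compare in this assay.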